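Taking one methoxy off compound 2

The compounds below may be only part of what the source reports. "The series", "measured", "known", "first", "only" and "open" are said of these compounds alone.

Of the compounds shown here, three have numbers so far in a functional assay on Jurkat cells (Homo sapiens) for cytotoxicity, read by MTT assay, with a stated time of 24 h; on this read-out higher numbers stand for an effect only at larger amounts of compound and lower numbers for an effect already at smaller amounts. Compound 1 (`CCOC(=O)c1cc([Se]c2ccccc2)c2cc(Br)ccc2n1`) gives 20800 nM, compound 2 (`CCOC(=O)c1cc([Se]c2ccc3cc(OC)ccc3c2)c2cc(OC)ccc2n1`) gives 31300 nM, and compound 3 (`CCOC(=O)c1cc(C#Cc2ccccc2[N+](=O)[O-])c2cc(OC)ccc2n1`) gives 54700 nM. Compound 2 stands in the middle of these three numbers, and its distance to each of the other two lies within the usual scatter of repeated measurements.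

Compound 4 (`CCOC(=O)c1cc([Se]c2ccc3ccccc3c2)c2cc(OC)ccc2n1`) has not been measured yet. It differs from compound 2 in one place: hydrogen in place of methoxy on an aromatic carbon. Put simply, this is hydrogen in place of methoxy on an aromatic carbon.

Within the data shown here, no two measured compounds differ in just one place, so the data hold no direct example of what this swap does. Among the measured compounds shown here, the only guide is indirect: compound 2 at 31300 nM lies within the scatter of both other compounds, even though their structures differ in more than one place. On that basis, no step beyond the scatter is expected in this assay, and no direction can be favoured with any confidence. The estimated change is a 1.1-fold lower number from compound 2 to compound 4 (0.05 log units; within the scatter), which would stay within the scatter. For compound 4 the estimated value is 28000 nM, with an expected range from 14000 nM to 56000 nM.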

Compound 4, half-maximal effective concentration: 50700 nM
Compound 4: the middle estimate sits 1.8-fold (0.26 log units) below what was measured; the range from low to high includes it.
By their numbers in this assay, from the lowest: compounds 1, 2, 4 and 3 (each within the scatter of the next, the first and the last beyond it).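

Among these compounds, for the first time, two compounds that differ in just one place can be compared directly: in this assay, there is a 1.6-fold higher number from compound 2 to compound 4 (0.21 log units; within the scatter) when hydrogen replaces methoxy on this aromatic carbon. Repeat measurements of one compound could differ this much, so the pair gives no firm sign that methoxy at this place matters for the read-out, in either direction. Nothing available ties this result to any property of the methoxy group or of the hydrogen.

The compounds shown leave open whether another group on this same carbon, such as an amine, a hydroxyl group or a longer chain like butoxy, would give a number beyond the scatter of compound 2. They also leave open whether the swap would look the same in another setting, for instance if the second methoxy group, which compound 2 and compound 4 share, gave way to hydrogen, since this single pair cannot show how general the result is.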